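The source may report more compounds than this note shows. Statements on the series, on what has been measured and on what is new or still open speak of the compounds shown alone.

Measured in a functional assay on MCF7 cells (Homo sapiens) for antiproliferative activity, read by MTT assay, with a stated time of 72 h; on this read-out lower numbers stand for stronger inhibition and higher numbers for weaker inhibition:
- Compound 1 `COc1cccc(N2C(=O)COc3ccc(-c4cnc(Cl)c(NS(=O)(=O)c5ccc(F)cc5)c4)cc32)c1`: > 40000 nM (a limit of the assay, not a number)
- Compound 2 `O=C1COc2ccc(-c3cccc(NS(=O)(=O)c4ccc(F)cc4)c3)cc2N1`: 18300 nM

Compound 1 has no numerical value and stands only on a limit: the limit of > 40000 nM in this assay, at which 1 of the 2 values shown sits. Compound 2 does give a number, 18300 nM.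

The next compound to be read in this assay is compound 3 `COc1ccc(N2C(=O)COc3ccc(-c4cnc(Cl)c(NS(=O)(=O)c5ccc(F)cc5)c4)cc32)cc1`, which has the same atoms as compound 1, joined differently. The change is 4-methoxyphenyl in place of 3-methoxyphenyl on an amide-type nitrogen in a ring, with the rest of the core of compound 1 unchanged. Among the compounds with values here, no pair of measured compounds shows what this exchange does in this assay.

Compound 1 offers only its limit of > 40000 nM as a starting point, and the two groups count the same. On that basis, the expected change is a number no higher from compound 1 to compound 3 (the limit leaves the size open), which would be no step beyond the usual scatter. A reading reported only as a limit would be no surprise. For compound 3 the estimated value is 40000 nM, with an expected range from 15000 nM to 80000 nM.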

Compound 3, half-maximal inhibitory concentration: 36000 nM
Estimate against measurement, compound 3: 1.1-fold (0.05 log units) above, and the stated range covers the measured number.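

In this assay, 4-methoxyphenyl on the amide-type nitrogen gives a measurable number where 3-methoxyphenyl did not: compound 3 reads 36000 nM. Compound 1 has only a limit of the assay, > 40000 nM. The exchange can therefore be read only as a floor, an at least 1.1-fold lower number from compound 1 to compound 3 (0.04 log units; that floor lies within the scatter), and its true size stays open, since the reading for compound 1 is bounded on one side only: the limit of > 40000 nM in this assay, at which 1 of the 3 values shown sits.

The compounds shown do not tell whether a methoxy group is needed on this ring at all, as none of them carries a plain phenyl, a dimethylamino group or a carboxylic acid in its place on the amide-type nitrogen. From the compounds shown here alone, compound 2 differs from compound 1 and compound 3 in more than one place, so its value cannot be tied to the group on that nitrogen, and the separate contribution of the chlorine on the shared core also remains unknown.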